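The compounds below may be only part of what the source reports. "The series", "measured", "known", "first", "only" and "open" are said of these compounds alone.

Of the compounds shown here, three with a shared core have been measured in a functional assay on L1210 cells (Mus musculus) for inhibition; a higher number here means a weaker inhibitor, a lower number a stronger inhibitor. Compound 1 `COC(=O)CNc1ncnc2c1C(=O)C(OC)=CC2=O` gives 1.2 ug/mL, compound 2 `CCCC(=O)OCCNc1ncnc2c1C(=O)C(OC)=CC2=O` gives 0.85 ug/mL, and compound 3 `CCN(CC)CCNc1ncnc2c1C(=O)C(OC)=CC2=O` gives 0.281 ug/mL, the lowest number of the three. Compound 4 `CCN(CC)CCCNc1ncnc2c1C(=O)C(OC)=CC2=O` alters the side chain of compound 3: (diethylamino)methyl in place of diethylamino on a saturated chain carbon, two bonds along the chain from a nitrogen on an aromatic ring. The measured steps all replace the group at the chain end. Both a 4.3-fold lower number from compound 1 to compound 3 (0.63 log units; beyond the scatter) and a 3.0-fold lower number from compound 2 to compound 3 (0.48 log units; beyond the scatter) are modest, while a 1.4-fold lower number from compound 1 to compound 2 (0.15 log units; within the scatter) stays within the scatter. None of them tests a longer chain, and compound 4 keeps the diethylamino group of compound 3 at 0.281 ug/mL, so no step beyond the scatter is expected. The expected change is a 1.1-fold higher number from compound 3 to compound 4 (0.03 log units; within the scatter). For compound 4 the estimated value is 0.3 ug/mL, with an expected range from 0.12 ug/mL to 0.75 ug/mL.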

Compound 4, half-maximal inhibitory concentration: 0.393 ug/mL
Estimate against measurement, compound 4: 1.3-fold (0.12 log units) below, and the stated range covers the measured number.
By their numbers in this assay, from the lowest: compounds 3 and 4 (each within the scatter of the next); then compounds 2 and 1 (each within the scatter of the next).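

In this assay, adding one chain carbon to the side chain of compound 3 gives a 1.4-fold higher number from compound 3 to compound 4 (0.15 log units; within the scatter), so the diethylamino end keeps its place among the lowest numbers at either chain length. The longer chain also stays clear of the other two end groups, with a 2.2-fold lower number from compound 2 to compound 4 (0.34 log units; beyond the scatter) and a 3.1-fold lower number from compound 1 to compound 4 (0.48 log units; beyond the scatter). No measurement here accounts for these steps.

Still open, on these data alone, is whether a longer chain would leave the number unchanged. As far as these compounds go, it is also open whether a ring amine such as piperidine or morpholine could stand in for diethylamino.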